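A few compounds are considered here, and "the series" means these few. Any claim that something is new, unique, unknown or untested is made for them only; others in the source may bear on it.

Compound 1 `N#CC1=C(N)Oc2c(c3nc4ccccc4nc3c3ccccc23)C12C(=O)N(Cc1cnnn1-c1cc(Cl)ccc1Cl)c1ccccc12` and compound 2 `N#CC1=C(N)Oc2c(N)cc3nc4ccccc4nc3c2C12C(=O)N(Cc1cnnn1-c1ccc(F)cc1)c1ccccc12` are two members of the same series, built on a shared core and carrying different groups at their periphery. In a functional assay on HCT-116 cells (Homo sapiens) for antiproliferative activity, read by MTT assay, with a stated time of 48 h (a lower number here means a stronger inhibitor, a higher number a weaker inhibitor), compound 1 gives > 50000 nM, which is a limit of the assay rather than a number. In this assay compound 2 likewise gives > 50000 nM, again a limit and not a number. Compound 2 therefore stands where compound 1 stands, at the limit of > 50000 nM in this assay, at which 2 of the 2 values shown sit, and the two values shown do not separate the two compounds in any direction. Among the compounds with values here, no step between measured compounds can be drawn from two limits.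

Compound 3 `CCOc1ccc(-n2nncc2CN2C(=O)C3(C(C#N)=C(N)Oc4c(N)cc5nc6ccccc6nc5c43)c3ccccc32)cc1` has not yet been measured. It differs from compound 2 by ethoxy in place of fluoro on an aromatic carbon. Within the data shown here, since both values known so far sit at the limit of > 50000 nM in this assay, at which 2 of the 2 values shown sit, compound 3 is expected to show no step beyond the scatter in this assay, that is, to remain at the limit as well. Compound 3 is estimated at 60000 nM, with a range from 20000 nM to 200000 nM. The expected step is a step that the limit leaves unreadable from compound 2 to compound 3.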

Compound 3, half-maximal inhibitory concentration: > 50000 nM
Compound 3 gave a limit, no number; the forecaster's own chance of this, stated with the estimate: 80%; the middle value is on the limit's open side.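

In this assay compound 3 gives > 50000 nM, a limit of the assay and not a number. No step can be read from compound 2 to compound 3, as each gives only a limit: the limit of > 50000 nM in this assay, at which 3 of the 3 values shown sit.

The compounds shown leave open whether the change from 4-fluorophenyl to 4-ethoxyphenyl alters antiproliferative activity at all.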